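Fluoro for trifluoromethyl on the aryl ring of a dienone

The source may hold more compounds than are shown below. What is called first, only, known or untested is meant among the compounds shown, and "the series" means these compounds.

Measured compounds:
- compound 1 `CC1=C(/C=C/C(=O)/C=C/c2ccccc2C(F)(F)F)C(C)(C)CCC1O`: 2300 nM
- compound 2 `CC1=C(/C=C/C(=O)/C=C/c2cccc(C(F)(F)F)c2)C(C)(C)CCC1O`: 1700 nM
- compound 3 `CC1=C(/C=C/C(=O)/C=C/c2cc(C(F)(F)F)ccc2C(F)(F)F)C(C)(C)CCC1O`: "not determined" (no result reported)

Compounds 1 and 2 share a core and differ only in where a single trifluoromethyl sits on the aromatic ring. In a functional assay on CWR22R cells (Homo sapiens) for cytotoxicity, read by MTT assay, with a stated time of 72 h (a higher number here means a weaker inhibitor, a lower number a stronger inhibitor), compound 1 gives 2300 nM, and in this assay compound 2 gives 1700 nM; these two values lie within the usual scatter of each other, so nothing separates them. Compound 3 carries trifluoromethyl twice on the same ring, but in this assay compound 3 gives "not determined" (no result reported), so it cannot be placed among the others.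

Compound 4 `CC1=C(/C=C/C(=O)/C=C/c2cc(C(F)(F)F)ccc2F)C(C)(C)CCC1O` arises from compound 3 by one change: fluoro in place of trifluoromethyl on an aromatic carbon. Among the measured compounds shown here, no step between measured compounds isolates this change, and compound 3 itself has no value to start from. The two measured analogues suggest that a ring with one or two fluorinated substituents stays near the low-micromolar range, and a step of this kind is expected to fall within the scatter rather than beyond it. For compound 4 in this assay the estimate is 2000 nM, with a likely range from 800 nM to 5000 nM.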

Compound 4, half-maximal inhibitory concentration: 2000 nM
Compound 4: the middle estimate sits on the measured number at the digits printed; the measured number falls inside the stated range.
By their numbers in this assay, from the lowest: compounds 2, 4 and 1 (each within the scatter of the next).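

In this assay, among the compounds shown here, the one readable step at this position is a 1.2-fold higher number from compound 2 to compound 4 (0.07 log units; within the scatter), with fluoro in place of hydrogen on an aromatic carbon that is ortho to a large group and para to a trifluoromethyl group. Compounds 1 and 2 differ only in where a single trifluoromethyl sits, so they said nothing about adding a substituent at this carbon; compound 4 shows that, with fluoro there, its number cannot be told apart from that of compound 2. The exchange of trifluoromethyl for fluoro itself cannot be read, since compound 3 has no value, and no measurement shown here speaks to the reason behind the result.

What the compounds shown leave open is whether this carbon would accept anything other than hydrogen or fluoro, such as a methoxy group, an amine or a carboxylic acid, without moving the number beyond the scatter. Also open, going by these compounds, is how trifluoromethyl at this carbon compares with fluoro or hydrogen, a comparison that would need a number for compound 3.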